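The source may report more compounds than this note shows. Statements on the series, on what has been measured and on what is new or still open speak of the compounds shown alone.

Of the compounds shown here, three sharing one core have been tested in a functional assay on HeLa cells (Homo sapiens) for antiproliferative activity, read by MTT assay, with a stated time of 48 h; on this read-out higher numbers stand for weaker inhibition and lower numbers for stronger inhibition. Compound 1 `C#Cc1cccc(Nc2ncnc3cc(NC(=O)/C=C/c4ccccc4)sc23)c1` gives 20500 nM, compound 2 `O=C(/C=C/c1ccccc1)Nc1cc2ncnc(Nc3cc(Cl)cc(Cl)c3)c2s1` gives 3210 nM, and compound 3 `O=C(/C=C/c1ccc(O)cc1)Nc1cc2c(Nc3ccc(Cl)c(Cl)c3)ncnc2s1` gives 24800 nM. Compound 2 stands lowest of the three, and its gaps to compound 1 and to compound 3 both lie beyond the scatter. For the measured compounds named here, the only measured step, a 6.4-fold lower number from compound 1 to compound 2 (0.81 log units; beyond the scatter), exchanges one aryl group for another on the same nitrogen. The unmeasured compound 4 `O=C(/C=C/c1ccccc1)Nc1cc2ncnc(Nc3ccc(Cl)c(Cl)c3)c2s1` differs from compound 2 by 3,4-dichlorophenyl in place of 3,5-dichlorophenyl on a nitrogen on an aromatic ring. Going by the values given here, no measured step isolates this change; compound 3 carries the entering group but differs in two further places, so its value is no direct guide. Compound 4 is therefore expected to stay near the value of compound 2. The expected step is a 1.6-fold higher number from compound 2 to compound 4 (0.19 log units; within the scatter), a modest move at most. Compound 4 is estimated at 5000 nM, with a range of 1500 nM to 16000 nM.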

Compound 4, half-maximal inhibitory concentration: 10700 nM
Compound 4: the middle estimate sits 2.1-fold (0.33 log units) below what was measured; the measured number falls inside the stated range.
By their numbers in this assay, from the lowest: compound 2; then compounds 4, 1 and 3 (each within the scatter of the next, the first and the last beyond it).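

In this assay the same two chlorines placed differently give a 3.3-fold higher number from compound 2 to compound 4 (0.52 log units; beyond the scatter), so 3,5-dichlorophenyl and 3,4-dichlorophenyl are not interchangeable on this nitrogen. Replacing 3-ethynylphenyl with 3,4-dichlorophenyl gives a 1.9-fold lower number from compound 1 to compound 4 (0.28 log units; within the scatter), so the clear gain seen with 3,5-dichlorophenyl does not carry over to this other dichlorophenyl group. Nothing available here explains this difference between the two chlorine arrangements. On these data alone, it remains open whether 3,5-difluorophenyl or 3,5-dimethoxyphenyl on this nitrogen would keep the number near that of compound 2.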